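The source may hold more compounds than are shown below. What is called first, only, known or untested is meant among the compounds shown, and "the series" means these compounds.

Measured in an ADME assay on microsomes from liver (Homo sapiens) for metabolic stability; on this read-out lower numbers stand for a shorter-lived compound and higher numbers for a longer-lived compound:
- Compound 1 `CC(C)C(c1ccc(-c2ccc3cccc(F)c3c2)[nH]c1=O)N1CCCCS1(=O)=O`: 0.373 h
- Compound 2 `CC(C)C(Nc1nnc[nH]1)c1ccc(-c2ccc3cccc(F)c3c2)[nH]c1=O`: > 3 h (a limit of the assay, not a number)
- Compound 3 `CCn1ncc2c(F)cc(-c3ccc(C(CC)(CC)c4nnc[nH]4)c(=O)[nH]3)cc21`: 2.7 h

Compound 2 is known only as a limit: the limit of > 3 h in this assay, at which 1 of the 3 values shown sits. Compound 4 `CC(C)C(Cc1nnc[nH]1)c1ccc(-c2ccc3cccc(F)c3c2)[nH]c1=O` differs from it as follows: (4H-1,2,4-triazol-3-yl)methyl in place of (4H-1,2,4-triazol-3-yl)amino on a saturated chain carbon bound to an aromatic carbon and a saturated chain carbon. In words, (4H-1,2,4-triazol-3-yl)methyl stands in place of (4H-1,2,4-triazol-3-yl)amino.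

Among the measured compounds shown here, the one measured step at this place is an at least 8.0-fold higher number from compound 1 to compound 2 (0.90 log units; beyond the scatter), and it brought in the (4H-1,2,4-triazol-3-yl)amino group against a quite different group. Compound 3, on a different core and with no amino link to its five-membered aromatic ring, gives 2.7 h. With compound 3 at that value, no change beyond the scatter is expected: a number no higher from compound 2 to compound 4 (the limit leaves the size open). The estimate in this assay for compound 4 is 3 h, with an expected range of 1.2 h to 6 h.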

Compound 4, half-life: 0.307 h
Compound 4: the middle estimate sits 9.8-fold (0.99 log units) above what was measured; measured number outside the range, below it.
By their numbers in this assay, from the lowest: compounds 4 and 1 (each within the scatter of the next); then compound 3. At a limit, above all of these: compound 2.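

In this assay, changing only the link to the triazole ring, with (4H-1,2,4-triazol-3-yl)methyl in place of (4H-1,2,4-triazol-3-yl)amino, gives an at least 9.7-fold lower number from compound 2 to compound 4 (0.98 log units; beyond the scatter). Compound 2 is known only as a limit, so this step has a minimum size and no upper bound: the limit of > 3 h in this assay, at which 1 of the 4 values shown sits. The triazole ring alone therefore does not secure the longer half-life, as the comparison with the group of compound 1 gives a 1.2-fold lower number from compound 1 to compound 4 (0.08 log units; within the scatter).

Going by these compounds, it remains open whether an ether oxygen or a methylated amine in the link would keep the half-life of the amino link. Also open, on these data alone, is whether the amino link would act the same way on the core of compound 3.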